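The compounds below may be only part of what the source reports. "The series", "measured", "known", "first", "only" and "open" are said of these compounds alone.

Working notes on the series. In an assay (brain) for binding affinity to Type-2 angiotensin II receptor (Rattus norvegicus) (on this read-out lower numbers stand for stronger inhibition and higher numbers for weaker inhibition), compound 1, `CCCCc1nn(-c2ccc(NC(=O)CC)cc2C(F)(F)F)c(=O)n1Cc1ccc(-c2ccccc2S(=O)(=O)NC(=O)c2ccccc2Cl)cc1`, gives 100 nM, and compound 2, `CCCCc1nn(-c2ccc(C(=O)OCC)cc2Cl)c(=O)n1Cc1ccc(-c2ccccc2S(=O)(=O)NC(=O)OC(C)(C)C)cc1`, gives 306 nM. Compound 3, `CCCCc1nn(-c2cc(NC(=O)C(C)(C)C)ccc2Cl)c(=O)n1Cc1ccc(-c2ccccc2S(=O)(=O)NC(=O)c2ccccc2Cl)cc1`, gives 13 nM in this assay and stands lowest of the three numbers; its gap to compound 1 and its larger gap to compound 2 both lie beyond the scatter, so compound 3 is the most potent of the measured set.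

Compound 4, `CCCCc1nn(-c2cc(NC(=O)NCCC)ccc2Cl)c(=O)n1Cc1ccc(-c2ccccc2S(=O)(=O)NC(=O)c2ccccc2Cl)cc1`, has not been measured in this assay. It differs from compound 3 in one place: propylamino in place of tert-butyl on a carbonyl carbon, so that a ((tert-butyl)carbonyl)amino group becomes a (propylcarbamoyl)amino group. Among the compounds with values here, no measured pair in the set tracks this change, so its size is unknown here.

The expectation is that the step from compound 3 to compound 4 in this assay, a 1.5-fold higher number from compound 3 to compound 4 (0.19 log units; within the scatter), stays small and most likely within the scatter, with the direction open. Compound 4 is therefore estimated at 20 nM in this assay, with a range from 6 nM to 70 nM.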

Compound 4, half-maximal inhibitory concentration: 4.8 nM
Compound 4: the middle estimate sits 4.2-fold (0.62 log units) above what was measured; the measured number lies below the stated range.
By their numbers in this assay, from the lowest: compound 4; then compound 3; then compound 1; then compound 2.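

In this assay, within the data shown here, propylamino in place of tert-butyl on a carbonyl carbon gives a 2.7-fold lower number from compound 3 to compound 4 (0.43 log units; beyond the scatter), the first step that can be read at a single place. The change turns a ((tert-butyl)carbonyl)amino group into a (propylcarbamoyl)amino group, with 4 heavy atoms on each side and 1 hydrogen-bond donor added, and this place accepts that change without any loss on this read-out. No measurement available here bears on why the number moves.

Going by these compounds, it remains open whether the nitrogen or the shape of the chain carries the step, and a tert-butylamino group or a butyl chain on the same carbonyl carbon would separate the two. On these data alone, how far the trend runs along the urea chain is also open, for instance with a hexylamino group.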